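A few compounds are considered here, and "the series" means these few. Any claim that something is new, unique, unknown or untested is made for them only; others in the source may bear on it.

In a functional assay on RPMI-8226 cells (Homo sapiens) for cytotoxicity, with a stated time of 72 h (on this read-out lower numbers stand for an effect already at smaller amounts and higher numbers for an effect only at larger amounts of compound), compound 1, with the structure `CC(C)=CCC/C(C)=C/Cc1c(O)cc2c(c1O)C(=O)C[C@@H](c1cc(O)cc(O)c1)O2`, gives 7100 nM. Among the measured compounds shown here, that is the only plain number among the three measured compounds. Compound 2, built as `COc1cc(O)c([C@@H]2CC(=O)c3c(O)cc(O)cc3O2)cc1C/C=C(\C)CCC=C(C)C`, reaches only > 10000 nM, which is a limit of the assay and not a value. Compound 3, built as `COc1cc([C@@H]2CC(=O)c3c(cc(O)c(C/C=C(\C)C/C=C/C(C)(C)O)c3O)O2)ccc1O`, likewise returns > 10000 nM, again a limit. Compound 1 therefore stands alone with a measured figure, and the rest of the picture is set by the limit of > 10000 nM in this assay, at which 2 of the 3 values shown sit.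

Compound 4, `COc1cc([C@@H]2CC(=O)c3c(cc(O)c(C/C=C(\C)CCC=C(C)C)c3O)O2)cc(O)c1O`, has not been tested. Set against compound 1, the change is 3,4-dihydroxy-5-methoxyphenyl in place of 3,5-dihydroxyphenyl on a saturated ring carbon. For the measured compounds named here, no measured pair differs in exactly this way, so the size of the step cannot be read off from the data. Compound 1 itself gives only the modest 7100 nM. The two other measured compounds add no plain number to that. Against that background the expected step of a 1.5-fold higher number from compound 1 to compound 4 (0.19 log units; within the scatter) points toward weaker activity, beyond the usual scatter. The estimate for compound 4 in this assay is 11000 nM, with a plausible range from 4000 nM to 30000 nM, and a good chance that the measurement comes back as a limit alone.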

Compound 4, half-maximal effective concentration: 7300 nM
Compound 4: the middle estimate sits 1.5-fold (0.18 log units) above what was measured; the measured number falls inside the stated range.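

In this assay, putting 3,4-dihydroxy-5-methoxyphenyl in place of 3,5-dihydroxyphenyl on the saturated ring carbon next to the ring oxygen gives a 1.0-fold higher number from compound 1 to compound 4 (0.01 log units; within the scatter). Among the compounds shown here, this is the first comparison in the set between two compounds that differ in only one place, and it gives a direct reading for this position, which the earlier compounds could not provide. The entering group has more heavy atoms and one more hydrogen-bond acceptor, yet the two compounds lie within the usual scatter of each other, so this particular swap has no detectable effect on the read-out.

One step on one aromatic group is a narrow basis, and the other compounds shown offer no plain number for a further comparison: the limit of > 10000 nM in this assay, at which 2 of the 4 values shown sit. It remains open whether a quite different group on this ring carbon, such as a phenyl ring carrying an amine or a carboxylic acid, would shift the number beyond the scatter, and whether any such result would carry over to a shorter or longer chain elsewhere on the shared core.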